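Aryl swap on the shared core and acid dissociation

The source may hold more compounds than are shown below. What is called first, only, known or untested is meant among the compounds shown, and "the series" means these compounds.

Measured so far:
compound 1 `CC(C)(C)c1ccc(-c2ccc3c(NCCCNCc4ccco4)ccnc3c2)cc1` gives 9.47
compound 2 `c1ccc(Cc2ccc3c(NCCCNCc4ccco4)ccnc3c2)cc1` gives 9.47
compound 3 `COc1ccc(F)cc1CNCCCNc1ccnc2cc(Cc3ccccc3)ccc12` gives 9.47

In a physicochemical assay for acid dissociation, compound 3 stands level with compounds 1 and 2 at the digits shown; its nearest neighbour is compound 1 and its furthest is compound 2, and in both cases the gap lies within the scatter. Compound 4 `COc1ccc(F)cc1CNCCCNc1ccnc2cc(-c3ccc(C(C)(C)C)cc3)ccc12` has not yet been measured. It differs from compound 3 in one place: 4-(tert-butyl)phenyl in place of benzyl on an aromatic carbon.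

One earlier step speaks to this change directly, since it exchanges the same two groups on the same aromatic carbon, only in the other direction: no change at the digits printed from compound 1 to compound 2 (within the scatter). The other step, no change at the digits printed from compound 2 to compound 3 (within the scatter), also left the read-out unchanged. Together they suggest that the shared core sets the value and that this aryl swap does not move it. The step is therefore expected to be no change at the digits printed from compound 3 to compound 4 (within the scatter), no change beyond the scatter. Compound 4 is estimated at 9.47, within a range from 9.17 to 9.77.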

Compound 4, acid dissociation constant: 9.47
Beside the measured number, compound 4's estimate shows no gap at the digits printed, and the stated range covers the measured number.
By their numbers in this assay, from the lowest: compounds 1, 2, 3 and 4 (each within the scatter of the next).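

In this assay, the exchange on this aromatic carbon now has a reading with 5-fluoro-2-methoxyphenyl on the saturated chain carbon, and that reading is no change at the digits printed from compound 3 to compound 4 (within the scatter). The change from furan-2-yl to 5-fluoro-2-methoxyphenyl likewise now has a reading with 4-(tert-butyl)phenyl on the aromatic carbon: no change at the digits printed from compound 1 to compound 4 (within the scatter). Each of the two changes has thus been read with both partners at the other place, and across these four compounds neither changes the outcome of the other beyond the scatter.

Nothing shown gives a reason for this flat result.

All four compounds keep the same shared core and the same saturated chain. Going by these compounds, whether an amine or a carboxylic acid on this aromatic carbon, or a longer chain, would move the value remains open.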